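Oxidising the sulfur link: from compound 3 to compound 4

The source may report more compounds than this note shows. Statements on the series, on what has been measured and on what is new or still open speak of the compounds shown alone.

Three compounds have a result in a functional assay on DU-145 cells (Homo sapiens) for inhibition, read by trypan blue exclusion, with a stated time of 96 h; a lower number here means a stronger inhibitor of growth, a higher number a weaker inhibitor of growth:

Compound 1 `O=C(O)c1ccc(C(=O)/C(=C\c2ccc(F)c([N+](=O)[O-])c2)SCc2ccc(Cl)cc2)cc1` gives 50000 nM.
Compound 2 `CSc1ccc(/C=C(\C(=O)c2ccc(Cl)cc2)S(=O)(=O)Cc2ccc(C)cc2)cc1` gives 10000 nM.
Compound 3 `COc1cc(OC)c(/C=C(/SCc2ccc(Cl)cc2)C(=O)c2ccc(Br)cc2)c(OC)c1` gives 1000 nM.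

Compound 3 holds the lowest of the three numbers; compound 2 is its nearest neighbour and sits beyond the scatter above it, compound 1 further still. No pair of these compounds differs in only one place, so no single step can be read from them. Compound 4 `COc1cc(OC)c(/C=C(\C(=O)c2ccc(Br)cc2)S(=O)(=O)Cc2ccc(Cl)cc2)c(OC)c1` keeps the core of compound 3 and differs by (4-chlorobenzyl)sulfonyl in place of (4-chlorobenzyl)sulfanyl on a double-bonded chain carbon bound to a carbonyl carbon and a double-bonded chain carbon. Going by the values given here, compound 2, the only measured compound bearing a sulfonyl, gives a higher number than compound 3, but it differs in several other places as well. The step is therefore expected to be a modest weakening, a 3.0-fold higher number from compound 3 to compound 4 (0.48 log units; beyond the scatter). Compound 4 is estimated at 3000 nM, within 700 nM to 15000 nM.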

Compound 4, concentration for 50% growth inhibition: 25000 nM
Beside the measured number, compound 4's estimate is 8.3-fold (0.92 log units) below it; measured number outside the range, above it.
By their numbers in this assay, from the lowest: compound 3; then compound 2; then compounds 4 and 1 (each within the scatter of the next).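

In this assay, going by these compounds alone, the first comparison that differs in only one place shows that this position responds strongly to oxidation of the sulfur link: (4-chlorobenzyl)sulfonyl in place of (4-chlorobenzyl)sulfanyl gives a 25-fold higher number from compound 3 to compound 4 (1.40 log units; beyond the scatter). On this core, the sulfanyl form therefore goes with the much stronger inhibition of growth. Nothing shown explains the loss. On these data alone, what a (4-chlorobenzyl)sulfinyl group or an amine link would give at this place stays open. So does whether the same step holds on the cores of compound 1 and compound 2.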